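The source may report more compounds than this note shows. Statements on the series, on what has been measured and on what is new or still open speak of the compounds shown alone.

In a functional assay on HL-60 cells (Homo sapiens) for inhibition, read by CCK-8 assay, with a stated time of 48 h (on this read-out lower numbers stand for stronger inhibition and higher numbers for weaker inhibition), compound 1 (`O=S(=O)(NCCNC(=S)Nc1cccc(Cl)c1)c1ccc(-c2ccccc2OCc2cccc(O)c2)s1`) gives 1800 nM. Compound 2 (`O=S(=O)(NCCNC(=S)Nc1cccc(Cl)c1)c1ccc(-c2ccccc2OCc2ccccc2)s1`) gives > 50000 nM, which is a limit and not a number, so it stands at the limit of > 50000 nM in this assay, at which 2 of the 3 values shown sit. Compound 3 (`COc1ccc(Oc2ccc([N+](=O)[O-])cc2-c2ccsc2S(=O)(=O)N2CCN(C(=S)Nc3ccc([N+](=O)[O-])cc3)CC2)cc1OC`) gives > 50000 nM, which is also a limit.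

The next compound to consider is compound 4 (`Cc1cc(C)cc(NC(=O)NCCNS(=O)(=O)c2ccc(-c3ccccc3OCc3ccccc3)s2)c1`). Compared with compound 2, it carries this change: a group of 11 heavy atoms (9 carbon, 1 nitrogen, 1 oxygen; one six-membered aromatic ring of carbon only) in place of a group of 10 heavy atoms (7 carbon, 1 nitrogen, 1 sulfur, 1 chlorine; one six-membered aromatic ring of carbon only), on an amine nitrogen. The (3,5-dimethylphenyl)carbamoyl group enters on an amine nitrogen.

Among the measured compounds shown here, only one measured step bears on this comparison, and only indirectly. That step, an at least 27-fold higher number from compound 1 to compound 2 (1.44 log units; beyond the scatter), is large and puts hydrogen in place of hydroxy on an aromatic carbon. Compound 4 has that same hydrogen, and the hydroxy of compound 1, with its 1800 nM, is not restored. For the measured compounds named here, no measured step covers the swap at the amine nitrogen, so no clear gain in this assay is expected, and any shift should be small. The expected change is an at least 1.2-fold lower number from compound 2 to compound 4 (0.09 log units; that floor lies within the scatter). For compound 4 the estimated value is 40000 nM, with an expected range of 12000 nM to 100000 nM.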

Compound 4, half-maximal inhibitory concentration: 2200 nM
Beside the measured number, compound 4's estimate is 18-fold (1.26 log units) above it; measured number below the stated range.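

The group on the amine nitrogen turns out to matter a great deal in this assay: replacing the chlorine- and sulfur-containing group of compound 2 with the (3,5-dimethylphenyl)carbamoyl group gives an at least 22-fold lower number from compound 2 to compound 4 (1.35 log units; beyond the scatter). Among the compounds shown here, until now, the only readable step lay at the hydroxy position, so this is a second place in the molecule where one change has a large effect, and here no hydroxy is needed for it. Compound 2 has only a limit, so this step has a floor rather than an exact size: the limit of > 50000 nM in this assay, at which 2 of the 4 values shown sit.

This swap changes sulfur to oxygen and chlorine to methyl groups at once, so the compounds shown cannot say which of these changes carries the step. Also open, on these data alone, is how a plain phenylcarbamoyl or an acetyl group on this nitrogen would behave, and whether a hydroxy added to compound 4 would change its value.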